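From hydroxy to fluoro on a growth-inhibiting core

The compounds below may be only part of what the source reports. "The series", "measured", "known", "first", "only" and "open" are said of these compounds alone.

In a functional assay on DU-145 cells (Homo sapiens) for cytotoxicity (on this read-out higher numbers stand for weaker inhibition of growth and lower numbers for stronger inhibition of growth), compound 1 (`COc1ccc(C2=C(c3ccc(SC)cc3)CC3CCCN3C2=O)cc1`) gives 900 nM. The hydroxy analogue, compound 2 (`CSc1ccc(C2=C(c3ccc(O)cc3)C(=O)N3CCCC3C2)cc1`), gives > 100000 nM, which is a limit and not a number. Compound 2 therefore has no exact position, only (the limit of > 100000 nM in this assay, at which 1 of the 2 values shown sits).

Compound 3 (`CSc1ccc(C2=C(c3ccc(F)cc3)C(=O)N3CCCC3C2)cc1`) has not yet been measured. It carries fluoro in place of hydroxy on an aromatic carbon, para to a large group, the change from 4-hydroxyphenyl to 4-fluorophenyl: fluoro in place of hydroxy on an aromatic carbon.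

For the measured compounds named here, one measured step bears on this change: an at least 110-fold higher number from compound 1 to compound 2 (2.04 log units; beyond the scatter). On these data alone, this large step put hydrogen in place of methyl on an oxygen on an aromatic ring, and its true size remains open. Like compound 1, compound 3 has no hydroxy at this place, so a large step towards a lower number, meaning stronger inhibition of growth, is expected in this assay. Fluoro is not methoxy, however, so the expectation stays wide. The expected change is an at least 33-fold lower number from compound 2 to compound 3 (1.52 log units; beyond the scatter). For compound 3 the estimated value is 3000 nM, within an expected range of 600 nM to 20000 nM.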

Compound 3, concentration for 50% growth inhibition: 500 nM
Beside the measured number, compound 3's estimate is 6.0-fold (0.78 log units) above it, and the stated range ends above it.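

In this assay, the change from 4-hydroxyphenyl to 4-fluorophenyl gives an at least 200-fold lower number from compound 2 to compound 3 (2.30 log units; beyond the scatter), so the loss of growth inhibition seen with hydroxy at this place is reversed by a second replacement and not by methoxy alone. Going directly between the two groups that replace hydroxy gives a 1.8-fold lower number from compound 1 to compound 3 (0.26 log units; within the scatter), so methoxy and fluoro cannot be told apart in this assay, despite being different groups, and both stand far from the hydroxy compound. The value for compound 2 is a limit and not a number, so the step from it has a minimum size but no fixed one: the limit of > 100000 nM in this assay, at which 1 of the 3 values shown sits.

With only hydroxy, methoxy and fluoro at this place, the compounds shown leave open what sets hydroxy apart from the other two, since a single pair of replacements cannot separate the hydrogen-bond donor counted on hydroxy from any other difference between these groups. They also leave open how an amine, a carboxylic acid or a longer chain such as butoxy would read at the same place on the shared core.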